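The source may hold more compounds than are shown below. What is called first, only, known or untested is meant among the compounds shown, and "the series" means these compounds.

Compound 2 `CC1CCN(C2CCN(S(=O)(=O)c3ccc(OCc4ccccc4)cc3)CC2)CC1` is the reference for this step. In an ADME assay on HCT-116 cells (Homo sapiens) for cytotoxicity, read by CellTiter-Glo, with a stated time of 72 h (a lower number here means a stronger inhibitor, a higher number a weaker inhibitor), compound 2 gives > 5000 nM, which is a limit of the assay rather than a measured number. Compound 1 `CC1CCN(C2CCN(S(=O)(=O)c3ccc(C(C)(C)C)cc3)CC2)CC1` shares the same core and differs only in the group carried on the aromatic carbon. In this assay compound 1 gives > 5000 nM, again a limit and not a number. Both values sit at the limit of > 5000 nM in this assay, at which 2 of the 2 values shown sit, so the step from compound 1 to compound 2 a step that the two limits leave unreadable from compound 1 to compound 2 cannot be read.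

Compound 3 `CC1CCN(C2CCN(S(=O)(=O)c3ccc(C(C)C)cc3)CC2)CC1` is the next compound to be measured. The change from compound 2 to compound 3 is isopropyl in place of benzyloxy on an aromatic carbon. Among the compounds with values here, the only comparison on hand is the pair of compound 1 and compound 2, and it gives no readable size, so it shows neither direction nor magnitude for an isopropyl group in place of benzyloxy. With tert-butyl and benzyloxy both leaving the two compounds at the limit, the isopropyl in compound 3 is expected to behave like them. Compound 3 is therefore expected to sit at the limit as well, with an estimate of 9000 nM within 3000 nM to 30000 nM, corresponding to an expected step that the limit leaves unreadable from compound 2 to compound 3.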

Compound 3, half-maximal inhibitory concentration: > 5000 nM
Compound 3 ended at the assay's limit (the forecaster's own chance of this, stated with the estimate: 85%); the middle value does not contradict the limit.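

In this assay compound 3 gives > 5000 nM, which is a limit of the assay and not a number. Compound 1 and compound 2 also stand at a limit, so no step among compound 1, compound 2 and compound 3 can be read: the limit of > 5000 nM in this assay, at which 3 of the 3 values shown sit.

The compounds shown leave open how tert-butyl, benzyloxy and isopropyl on the aromatic carbon compare in this assay.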